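The source may hold more compounds than are shown below. What is called first, only, known or untested is meant among the compounds shown, and "the series" means these compounds.

Measured compounds:
compound 1, `CCCc1nc(CC)c(C(=O)OCc2ccccc2S(=O)(=O)c2ccccc2)n1Cc1ccc(-c2ccccc2S(=O)(=O)NC(=O)OCCC(C)C)cc1F`, 5 nM
compound 2, `CCCCN(Cc1ccccc1)C(=O)C#CCOC(=O)c1c(CC)nc(CCC)n1Cc1ccc(-c2ccccc2-c2nn[nH]n2)cc1`, 400 nM
compound 3, `CCCc1nc(CC)c(C(=O)OCc2ccc(C(=O)N(c3ccccc3)c3ccccc3)cc2)n1Cc1ccc(-c2ccccc2-c2nn[nH]n2)cc1`, 200 nM

Three compounds of the same family have been characterised in an assay on isolated protein for binding affinity to Type-2 angiotensin II receptor (Homo sapiens); a lower number here means a stronger inhibitor, a higher number a weaker inhibitor. Compound 1 gives the lowest number of the three, with 5 nM. Compound 3 gives 200 nM, and compound 2 gives 400 nM; both gaps from compound 1 lie beyond the usual scatter, so compound 1 stands as the strongest binder among the three measured compounds. Among the compounds with values here, compounds 2 and 3 differ from compound 1 at more than one place, and no single-change step between measured compounds is available, so the comparisons say only what their values show.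

The next compound in the series is compound 4, `CCCc1nc(CC)c(C(=O)OCc2ccccc2-c2ccccc2)n1Cc1ccc(-c2ccccc2S(=O)(=O)NC(=O)OCCC(C)C)cc1F`. It differs from compound 1 at one place: phenyl in place of phenylsulfonyl on an aromatic carbon. Within the data shown here, no measured pair reports the effect of this particular change, so the expectation rests on the position of compound 1 alone. The change keeps the rest of compound 1 intact, and a small loss in this assay is expected, of the size a 3.0-fold higher number from compound 1 to compound 4 (0.48 log units; beyond the scatter), although a result within the scatter of compound 1 would not be surprising. Compound 4 is therefore estimated at 15 nM, within a range from 4 nM to 60 nM.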

Compound 4, half-maximal inhibitory concentration: 9 nM
The estimate for compound 4 lay 1.7-fold (0.22 log units) above the measured number; the range from low to high includes it.
By their numbers in this assay, from the lowest: compounds 1 and 4 (each within the scatter of the next); then compounds 3 and 2 (each within the scatter of the next).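

In this assay, within the data shown here, the exchange of phenylsulfonyl for phenyl on an aromatic carbon of a six-membered aromatic ring, ortho to a large group, reads as a 1.8-fold higher number from compound 1 to compound 4 (0.26 log units; within the scatter), and this is the first single-change step available. The step shows that, with the rest of compound 1 held constant, the phenylsulfonyl group is not needed to keep the number in the same range: phenyl, with fewer heavy atoms and no hydrogen-bond acceptors, gives a value that cannot be told apart from that of compound 1. What can be said of this place therefore rests on one pair, and it holds only for these two groups on this particular core.

The compounds shown leave open how this place responds to groups of another kind, such as a carboxylic acid, an amine or a saturated cyclohexyl ring on the same aromatic carbon, and whether the same exchange would give a similar step with the rest of the molecule changed. No measurement at hand accounts for the size of this step.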